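A few compounds are considered here, and "the series" means these few. Any claim that something is new, unique, unknown or untested is made for them only; others in the source may bear on it.

Measured compounds in a functional assay on HCT-116 cells (Homo sapiens) for inhibition, read by MTT assay, with a stated time of 48 h; on this read-out higher numbers stand for weaker inhibition and lower numbers for stronger inhibition:
- compound 1 `Clc1ccc(CSc2nnc(-c3ccncc3)n2-c2ccccc2)cc1`: 10700 nM
- compound 2 `c1ccc(CSc2nnc(-c3ccncc3)n2-c2ccccc2)cc1`: 16900 nM
- compound 3 `O=C(CSc1nnc(-c2ccncc2)n1-c1ccccc1)N/N=C/c1ccc([N+](=O)[O-])cc1`: 10200 nM

Compound 3 gives the lowest of the three numbers, but its nearest neighbour compound 1 and its furthest neighbour compound 2 both lie within the scatter of it, so no order among the three can be read.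

Compound 4 `O=C(CSc1nnc(-c2ccncc2)n1-c1ccccc1)N/N=C/c1ccc(Br)cc1` differs from compound 3 by bromo in place of nitro on an aromatic carbon. Within the data shown here, the only measured single-point step is a 1.6-fold higher number from compound 1 to compound 2 (0.20 log units; within the scatter), a halogen-for-hydrogen swap on a different aromatic ring of the shared core; it bears on the present change only loosely, and it stayed within the scatter. No step beyond the scatter is therefore expected in this assay for compound 4.

Compound 4 is expected at 10000 nM, with a range from 4000 nM to 25000 nM. The expected step is a 1.0-fold lower number from compound 3 to compound 4 (0.01 log units; within the scatter).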

Compound 4, half-maximal inhibitory concentration: 4500 nM
For compound 4 the middle estimate is 2.2-fold (0.35 log units) above the measured one, and the stated range covers the measured number.
By their numbers in this assay, from the lowest: compound 4; then compounds 3, 1 and 2 (each within the scatter of the next).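

Among these compounds, the exchange of 4-nitrophenyl for 4-bromophenyl, on an aromatic carbon para to a large group, is the first single-place change to pass the scatter in this assay, with a 2.3-fold lower number from compound 3 to compound 4 (0.36 log units; beyond the scatter), though the step is modest. The earlier chloro-to-hydrogen step, on another ring, stayed within the scatter. Nothing measured here explains the step.

Going by these compounds, whether the step reflects the entry of bromo or the departure of nitro stays open. A 4-aminophenyl or 4-methoxyphenyl group at this place would help separate the two.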